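Shortening one linker in a symmetric bis-benzothiazolone piperazine

The compounds below may be only part of what the source reports. "The series", "measured", "known", "first", "only" and "open" are said of these compounds alone.

Measured compounds:
- compound 1, `O=c1sc2ccccc2n1CCCCN1CCN(CCCCn2c(=O)sc3ccccc32)CC1`: 2280 nM
- compound 2, `O=c1sc2ccccc2n1CCCCCN1CCN(CCn2c(=O)sc3ccccc32)CC1`: 1710 nM
- compound 3, `O=c1sc2ccccc2n1CCCCCCN1CCN(CCn2c(=O)sc3ccccc32)CC1`: 2950 nM

All three compounds share a central piperazine carrying two benzothiazolone-bearing chains, and they were tested in an assay on SW1353 cells (Homo sapiens) for inhibition, read by a luciferase reporter, with stated times of 30 min and 8 h; on this read-out higher numbers stand for weaker inhibition and lower numbers for stronger inhibition. Compound 1 gives 2280 nM, compound 2 gives 1710 nM and compound 3 gives 2950 nM, and each pair of these values lies within the usual scatter of one another, so no order among them can be claimed.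

Within the data shown here, the one measured step is a 1.7-fold lower number from compound 3 to compound 2 (0.24 log units; within the scatter). The change is a group of 10 heavy atoms (7 carbon, 1 nitrogen, 1 oxygen, 1 sulfur; one five-membered aromatic ring with 2 hetero atoms, one six-membered aromatic ring of carbon only) in place of a group of 11 heavy atoms (8 carbon, 1 nitrogen, 1 oxygen, 1 sulfur; one five-membered aromatic ring with 2 hetero atoms, one six-membered aromatic ring of carbon only), on a saturated chain carbon, five bonds along the chain from an amine nitrogen in a ring. Compound 1 and compound 3 contain the same atoms joined differently; the difference between the two cores is not broken down here.

The unmeasured compound 4, `O=c1sc2ccccc2n1CCCCN1CCN(CCCn2c(=O)sc3ccccc32)CC1`, arises from compound 1 by a group of 10 heavy atoms (7 carbon, 1 nitrogen, 1 oxygen, 1 sulfur; one five-membered aromatic ring with 2 hetero atoms, one six-membered aromatic ring of carbon only) in place of a group of 11 heavy atoms (8 carbon, 1 nitrogen, 1 oxygen, 1 sulfur; one five-membered aromatic ring with 2 hetero atoms, one six-membered aromatic ring of carbon only), on a saturated chain carbon, three bonds along the chain from an amine nitrogen in a ring. This is the same kind of change as that from compound 3 to compound 2, but not the same: there the place was five bonds along the chain from an amine nitrogen in a ring, here it is three bonds along the chain. Because the earlier step of a 1.7-fold lower number from compound 3 to compound 2 (0.24 log units; within the scatter) stayed within the scatter, and because compound 1 sits at 2280 nM close to its neighbours, compound 4 is expected to show a step of a 1.2-fold lower number from compound 1 to compound 4 (0.08 log units; within the scatter). The estimate for compound 4 in this assay is 1900 nM, expected to fall between 800 nM and 4500 nM.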

Compound 4, half-maximal inhibitory concentration: 1710 nM
Compound 4: middle estimate off by 1.1-fold (0.05 log units), on the high side; the range from low to high includes it.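

In this assay the new step is a 1.3-fold lower number from compound 1 to compound 4 (0.12 log units; within the scatter), so on the core of compound 1 this swap of one chain-bearing group for a shorter one gives a result that cannot be told apart from no change at all. Set beside the earlier case, the same kind of swap on a second core gives a step that cannot be told apart from the new one: the same change on two cores in this assay, a 1.7-fold lower number (0.24 log units; within the scatter) from compound 3 to compound 2 and a 1.3-fold lower number (0.12 log units; within the scatter) from compound 1 to compound 4, 1.3-fold (0.11 log units) apart, within the scatter of two such steps. This shows that, on these two cores, the change carries over without any detectable difference in its size, but both steps lie within the scatter, so it does not show that the shorter chain helps or harms on either core, and two cores are too few to make a rule for the whole series.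

The compounds shown leave open how far the chains can be altered before the number moves beyond the scatter, for example with a much longer chain or a much shorter one on either side of the piperazine. They also leave open what would follow from putting a different group on the chain or on the benzothiazolone, such as an amine, a carboxylic acid or a chlorine atom.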